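The source may report more compounds than this note shows. Statements on the series, on what has been measured and on what is new or still open speak of the compounds shown alone.

The measured compounds:

compound 1, `COc1ccc(-c2cc3cccc(OC)c3oc2=O)cc1`
compound 2, `CC(=O)Oc1cccc2cc(-c3ccccc3)c(=O)oc12`
compound 3, `CC(=O)Oc1ccc2cc(-c3ccccc3)c(=O)oc2c1OC(C)=O`

In an assay on CHO cells for displacement of a labelled ligand from adenosine receptor A1 (Homo sapiens), read by radioligand binding (on this read-out lower numbers stand for stronger inhibition and higher numbers for weaker inhibition), compound 2 gives 6930 nM, and compound 3 gives 8560 nM. For compound 1 the reading is only a limit of the assay, > 100000 nM. Compound 3 thus carries the higher of the two numbers, with compound 2 nearest; the step of a 1.2-fold higher number from compound 2 to compound 3 (0.09 log units; within the scatter) came from an acetoxy entering in place of hydrogen on an aromatic carbon of the shared core.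

Compound 4, `CC(=O)Oc1ccc(-c2cc3ccc(OC(C)=O)c(OC(C)=O)c3oc2=O)cc1`, differs from compound 3 by acetoxy in place of hydrogen on an aromatic carbon. Going by the values given here, the one measured step of the same kind, a 1.2-fold higher number from compound 2 to compound 3 (0.09 log units; within the scatter), stayed within the scatter, though it occurred on a different ring. Compound 1 shows that an analogue with a methoxy on the outer ring and a methoxy on the core reached only the limit, so some weakening cannot be ruled out. Compound 4 is therefore expected to change only modestly, a 1.5-fold higher number from compound 3 to compound 4 (0.18 log units; within the scatter), with an estimate of 13000 nM in this assay and a range of 4000 nM to 60000 nM.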

Compound 4, inhibition constant: > 100000 nM
Compound 4 ended at the assay's limit; the forecaster's own chance of this, stated with the estimate: 25%; at least 7.6-fold (0.88 log units) between middle value and limit.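

In this assay, acetoxy in place of hydrogen proves to depend on where it enters: on this six-membered aromatic ring of carbon only, para to a large group, it gives an at least 11-fold higher number from compound 3 to compound 4 (1.06 log units; beyond the scatter), whereas the same replacement at the other place gave a 1.2-fold higher number from compound 2 to compound 3 (0.09 log units; within the scatter). The earlier pair alone suggested that this replacement made no readable difference, and the new step shows that this does not hold for every position. On these data alone, the reading for compound 4 is a limit and not a number, so the full size of the step stays unknown: the limit of > 100000 nM in this assay, at which 2 of the 4 values shown sit.

As far as these compounds go, whether the loss belongs to the acetoxy itself or would follow any group at this place remains open. A hydroxyl or an amine there, with the rest of compound 3 unchanged, would help to separate the two.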